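The compounds below may be only part of what the source reports. "The series", "measured", "known", "first", "only" and "open" are said of these compounds alone.

Measured so far:
- compound 1, `CCC[C@@H](OC(C)=O)C1=C(Br)/C(=C/Br)OC1=O`: 0.8 ug/mL
- compound 2, `CCC[C@@H](OC(C)=O)C1=C(Br)[C@@](C)(OC)OC1=O`: 5.4 ug/mL

Of the compounds shown here, two have been tested in a functional assay on KB cells (Homo sapiens) for cytotoxicity; on this read-out higher numbers stand for an effect only at larger amounts of compound and lower numbers for an effect already at smaller amounts. Compound 1 gives 0.8 ug/mL in this assay, and compound 2 gives 5.4 ug/mL. Of these two numbers, compound 1 has the lower one, and the gap between compound 1 and compound 2 lies beyond the usual scatter of the measurement, so compound 1 is the one acting at the smaller amount.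

The next compound, compound 3, `CCCCC1=C(Br)/C(=C/Br)OC1=O`, keeps the core of compound 1 and changes only one spot: hydrogen in place of acetoxy on a saturated chain carbon bound to a double-bonded ring carbon and a saturated chain carbon. In plain terms, the acetoxy group is removed and a hydrogen takes its place, so compound 3 is a smaller and simpler version of compound 1.

Among the compounds with values here, nothing measured here shows directly what removing this group does, since no two tested compounds differ by exactly this change. The expectation is that the step from compound 1 to compound 3 is a modest one, toward a somewhat higher number, estimated as a 2.5-fold higher number from compound 1 to compound 3 (0.40 log units; beyond the scatter). On that basis compound 3 is expected to give about 2 ug/mL in this assay, with a likely range from 0.6 ug/mL to 6 ug/mL.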

Compound 3, concentration for half-maximal effect: > 20 ug/mL
Compound 3 was reported as a limit; the forecaster's own chance of this, stated with the estimate: 5%; middle value at least 10-fold (1.00 log units) away from the limit.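

In this assay compound 3 gives > 20 ug/mL, a limit of the assay and not a number. Within the data shown here, putting hydrogen in place of acetoxy on this saturated chain carbon gives an at least 25-fold higher number from compound 1 to compound 3 (1.39 log units; beyond the scatter), the first reading of a change in one place, and it shows that the core of compound 1 alone does not carry the effect seen with acetoxy present. The true size of this step stays unknown because the value of compound 3 is a limit: the limit of > 20 ug/mL in this assay, at which 1 of the 3 values shown sits.

As far as these compounds go, what the acetoxy group contributes at this carbon remains open, since a hydroxy group, an amine or a longer ester such as butyryloxy in the same place would show whether the whole acetoxy group matters or only the oxygen attached to the chain. It is also unclear whether the same swap would cost as much on the core of compound 2, which keeps acetoxy but differs from compound 1 elsewhere.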